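A larger ring on the chain of compound 1

The source may report more compounds than this note shows. Statements on the series, on what has been measured and on what is new or still open speak of the compounds shown alone.

- Compound 1 `CC1=C(c2cccc(O)c2)C(c2ccc(OC[C@@H](C)N3CCCC3)cc2)Oc2ccc(O)cc21` gives 0.2 nM 
- Compound 2 `CC1=C(c2cccc(C#N)c2)C(c2ccc(OC[C@H](C)N3CC[C@@H](C)C3)cc2)Oc2ccc(O)cc21` gives 2.6 nM 

Both compounds were tested in a functional assay on MCF7 cells (Homo sapiens) for antiproliferative activity, read by CellTiter-Glo, with a stated time of 5 days (a higher number here means a weaker inhibitor, a lower number a stronger inhibitor), and compound 1 holds the lower number of the two, with compound 2 lying above it by more than the scatter of repeated measurements. The next compound to be examined is compound 3 `CC1=C(c2cccc(O)c2)C(c2ccc(OC[C@H](C)N3CCCCCC3)cc2)Oc2ccc(O)cc21` and it departs from compound 1 as follows: a group of 9 heavy atoms (8 carbon, 1 nitrogen; one seven-membered non-aromatic ring with 1 hetero atom) in place of a group of 7 heavy atoms (6 carbon, 1 nitrogen; one five-membered non-aromatic ring with 1 hetero atom), on a saturated chain carbon bound to an oxygen on an aromatic ring. Among the compounds with values here, no step between measured compounds that differ in only one place is available, so the data offer no direct guide to this change. Within the data shown here, compound 1 and compound 2 differ in more than one place, and compound 2 gives 2.6 nM as the only other number at hand. Compound 1 sits at 0.2 nM as the lower of just two values, so a modest move towards a weaker inhibitor is the more likely outcome. The expected shift is a 4.0-fold higher number from compound 1 to compound 3 (0.60 log units; beyond the scatter) and this estimate lies somewhat beyond the scatter. For compound 3 the expected value is 0.8 nM with an estimated range from 0.2 nM to 4 nM in this assay as the measurement still to come.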

Compound 3, half-maximal inhibitory concentration: 0.2 nM
For compound 3 the middle estimate is 4.0-fold (0.60 log units) above the measured one; the measured number falls inside the stated range.
By their numbers in this assay, from the lowest: compounds 1 and 3 (each within the scatter of the next); then compound 2.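

In this assay, within the data shown here, the one seven-membered non-aromatic ring with 1 hetero atom, put in place of the one five-membered non-aromatic ring with 1 hetero atom, gives no change at the digits printed from compound 1 to compound 3 (within the scatter) and so provides the first comparison that isolates a single place. The two earlier compounds differed in more than one place and could not speak to this position, whereas this pair shows that, on a saturated chain carbon bound to an oxygen on an aromatic ring, the group of 9 heavy atoms is tolerated as well as the group of 7 heavy atoms on the core of compound 1. Nothing available accounts for this result, so the reason for it remains unknown.

The compounds shown leave open whether a six-membered piperidine ring, a morpholine ring or an open-chain diethylamino group on the same chain would match compound 1 and compound 3 in this assay as well. A single pair also cannot show whether the same tolerance extends to an eight-membered nitrogen ring or holds when the hydroxyl on the phenyl ring is replaced by a nitrile.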